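Swapping a cyclohexyl for a cyclopentyl on the amide

The compounds below may be only part of what the source reports. "The series", "measured", "known", "first", "only" and "open" are said of these compounds alone.

Measured compounds:
Compound 1, `CCC(C)C(NC(=O)n1nnc2ccccc21)C(=O)NC1CCCCC1`: in a functional assay on HeLa cells (Homo sapiens) for inhibition (on this read-out lower numbers stand for stronger inhibition and higher numbers for weaker inhibition), compound 1 gives 63900 nM.
Compound 2, `O=C1NC(c2ccccc2)C(=O)N1Cc1ccccc1`: in this assay compound 2 gives > 100000 nM, which is a limit of the assay, not a number.
Compound 3, `O=C1NC(c2ccccc2)C(=O)N1C1CCCC1`: in this assay compound 3 gives > 100000 nM, again a limit of the assay.

Within the data shown here, compound 1 therefore stands as the only compound with an actual number; the other two are limits, and that is all those two values show. Compounds 2 and 3 share a different core from compound 1, so no change between them and compound 1 is counted.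

The compound still to be measured is compound 4, `CCC(C)C(NC(=O)n1nnc2ccccc21)C(=O)NC1CCCC1`. It differs from compound 1 in one place: cyclopentyl in place of cyclohexyl on an amide-type nitrogen. Among the measured compounds shown here, no measured pair shows what such a change does here, so the expectation rests on the change being small. The step of a 1.2-fold higher number from compound 1 to compound 4 (0.07 log units; within the scatter) is what is expected, a shift no larger than the usual scatter, in either direction. Compound 4 is estimated at 75000 nM, within 25000 nM to 200000 nM.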

Compound 4, half-maximal inhibitory concentration: 82300 nM
For compound 4 the middle estimate is 1.1-fold (0.04 log units) below the measured one; low and high end bracket the measured number.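

In this assay, cyclopentyl in place of cyclohexyl on an amide-type nitrogen gives a 1.3-fold higher number from compound 1 to compound 4 (0.11 log units; within the scatter), so the two compounds cannot be told apart on this read-out. Among these compounds, this pair is the first direct look at this position, and it shows that a five-membered carbon ring serves as well as a six-membered one here, with no gain in inhibition. Both numbers are weak and lie close to the top of what this assay can report, which leaves little room to see any further weakening: the limit of > 100000 nM in this assay, at which 2 of the 4 values shown sit.

Going by these compounds, whether anything other than a plain carbon ring would change the result stays open, for instance an amine or a carboxylic acid on the ring, or a longer chain in its place. A single pair also sets no pattern for this position.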